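This account rests on a few compounds, and the source may have more. Where it says the series, first, only, none or still open, it means among the compounds named here.

In a functional assay on PC-3 cells (Homo sapiens) for cytotoxicity, read by MTT assay, with a stated time of 48 h (on this read-out lower numbers stand for stronger inhibition and higher numbers for weaker inhibition), three close relatives of a shared core have been measured. Compound 1 `COc1cc(-c2nnc3n2NC(c2cccs2)C(C(=O)c2ccccc2)S3)cc(OC)c1OC` gives 86300 nM. Compound 3 `COc1ccc(C(=O)C2Sc3nnc(-c4cc(OC)c(OC)c(OC)c4)n3NC2c2cccs2)cc1` gives 95900 nM. Compound 2 `COc1ccc(C(=O)C2Sc3nnc(-c4cc(OC)c(OC)c(OC)c4)n3NC2c2ccco2)cc1` reaches only the limit of the assay, > 100000 nM, so no number is known for it. The step of a 1.1-fold higher number from compound 1 to compound 3 (0.05 log units; within the scatter) shows that methoxy in place of hydrogen on an aromatic carbon left the read-out unchanged. The step of an at least 1.0-fold lower number from compound 2 to compound 3 (0.01 log units; that floor lies within the scatter) likewise shows nothing beyond the scatter, and the floor set by the limit of > 100000 nM in this assay, at which 1 of the 3 values shown sits, covers it.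

Compound 4 `COc1cc(-c2nnc3n2NC(c2ccco2)C(C(=O)c2ccc(C(F)(F)F)cc2)S3)cc(OC)c1OC` differs from compound 2 by trifluoromethyl in place of methoxy on an aromatic carbon. Neither measured step tests a trifluoromethyl. Among the compounds with values here, the only change at that same place that has been measured, hydrogen to methoxy, moved nothing, and compound 2 itself sits at the limit. The expected step is therefore a number no higher from compound 2 to compound 4 (the limit leaves the size open), nothing beyond the scatter. Compound 4 is estimated at 100000 nM, in the range from 50000 nM to 200000 nM, with a fair chance that the assay again reports only a limit.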

Compound 4, half-maximal inhibitory concentration: 77500 nM
Beside the measured number, compound 4's estimate is 1.3-fold (0.11 log units) above it, and the stated range covers the measured number.
By their numbers in this assay, from the lowest: compounds 4, 1 and 3 (each within the scatter of the next). At a limit, above all of these: compound 2.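

In this assay, the change from 4-methoxyphenyl to 4-(trifluoromethyl)phenyl gives an at least 1.2-fold lower number from compound 2 to compound 4 (0.11 log units; that floor lies within the scatter). So far, this place had been compared only between hydrogen and methoxy with a thiophen-2-yl group on the saturated ring carbon; this step extends the comparison to a furan-2-yl compound and a fluorine-bearing group, and it too shows nothing beyond the scatter. The true size of the step stays open because compound 2 is known only as a limit of the assay: the limit of > 100000 nM in this assay, at which 1 of the 4 values shown sits.

The compounds shown leave open whether any group at this place can move the read-out beyond the scatter, since an amine, a nitrile and a carboxylic acid are not among them. They also leave open how a plain phenyl ketone would read with furan-2-yl on the saturated ring carbon.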